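The compounds below may be only part of what the source reports. "The series", "measured", "known", "first", "only" and "open" are said of these compounds alone.

Working notes on the series. Compound 1 `COc1ccc(O)c(/C=N/NC(=O)c2ccc(-c3nc4ccccc4s3)cc2)c1` carries the shared core with a hydroxy- and methoxy-bearing aryl group on the carbon double-bonded to nitrogen; in an assay on isolated protein for inhibition of Maltase-glucoamylase (Homo sapiens), with a stated time of 15 min (on this read-out higher numbers stand for weaker inhibition and lower numbers for stronger inhibition), compound 1 gives 6500 nM. Compound 2 `O=C(N/N=C/c1cccnc1)c1ccc(-c2nc3ccccc3s2)cc1` carries a pyridinyl on that carbon, and in this assay compound 2 is reported as "not active" (no number reported), with no number given. Compound 3 `O=C(N/N=C/c1ccccc1O)c1ccc(-c2nc3ccccc3s2)cc1` gives 5550 nM in this assay. It is the nearest analogue of compound 1: a 1.2-fold lower number from compound 1 to compound 3 (0.07 log units; within the scatter). Of the two numbers in hand, compound 3 shows the lower one, compound 1 sits within the scatter of it, and compound 2 stands apart without a number.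

Compound 4 `COc1ccc(/C=N/NC(=O)c2ccc(-c3nc4ccccc4s3)cc2)cc1OC` has not yet been measured in this assay. It differs from compound 3 in one place: 3,4-dimethoxyphenyl in place of 2-hydroxyphenyl on a carbon with a double bond to nitrogen. Among the measured compounds shown here, the only measured step touching this aryl group is the one from compound 1 to compound 3, and it lies within the scatter, so removing a methoxy changed little there; compound 2, however, shows that a different aryl at this carbon can remove measurable activity altogether. The hydroxy leaves and methoxy groups enter, so the expected step is small and upward, a 1.4-fold higher number from compound 3 to compound 4 (0.16 log units; within the scatter). The estimate for compound 4 in this assay is 8000 nM, with a range from 3000 nM to 25000 nM, and a real chance that only a limit is reported.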

Compound 4, half-maximal inhibitory concentration: "not active" (no number reported)
Compound 4: no number reported, so the estimate cannot be set against anything.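

Among the compounds shown here, compound 4, like compound 2, is reported in this assay without a number, so no step from compound 3 to compound 4 can be read. Nothing shown here offers an explanation for this result. The compounds shown leave open whether removing the hydroxy or adding the methoxy groups matters more, as no compound separates these changes.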